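Swapping the fluorophenyl amide on a shared core

A few compounds are considered here, and "the series" means these few. Any claim that something is new, unique, unknown or untested is made for them only; others in the source may bear on it.

Measured compounds:
compound 1 `CN(C)C(=O)c1cc2cnc(Nc3ccc(NC(=O)C4(C(=O)Nc5ccccc5F)CC4)cc3)nc2n1C1CCCC1` — 58%
compound 2 `CN(C)C(=O)c1cc2cnc(Nc3ccc(NC(=O)C4(C(=O)Nc5ccc(F)cc5)CC4)cc3F)nc2n1C1CCCC1` — -0.9%
compound 3 `CN(C)C(=O)c1cc2cnc(Nc3ccc(NC(=O)C4(C(=O)Nc5cccc(Br)c5)CC4)cc3)nc2n1C1CCCC1` — 0.04%

In a functional assay on OVCAR-5 cells (Homo sapiens) for inhibition, read by CCK-8 assay, with a stated time of 72 h, tested at 1 uM (on this read-out higher numbers stand for more inhibition of growth at the one concentration tested and lower numbers for less inhibition of growth), compound 1 stands highest of the three numbers; compound 3 and compound 2 both lie far below it, beyond the scatter. Compound 4 `CN(C)C(=O)c1cc2cnc(Nc3ccc(NC(=O)C4(C(=O)Nc5ccc(F)cc5)CC4)cc3)nc2n1C1CCCC1` is not yet measured. It differs from compound 1 in one place: 4-fluorophenyl in place of 2-fluorophenyl on an amide-type nitrogen. Among the measured compounds shown here, one measured step bears on this position, a number 58 percentage points lower from compound 1 to compound 3 (beyond the scatter), a large loss. Compound 2 also carries a 4-fluorophenyl on that amide nitrogen, though it differs from compound 1 in one more place, and its value is near zero. Compound 4 is therefore expected to fall well below compound 1, by a step of about a number 50 percentage points lower from compound 1 to compound 4 (beyond the scatter). The estimate for compound 4 is 8%, with a range from -10% to 35%.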

Compound 4, percent growth inhibition at one concentration: 65.4%
Estimate against measurement, compound 4: 57.4 percentage points below, and the stated range ends below it.
By their numbers in this assay, from the lowest: compounds 2 and 3 (each within the scatter of the next); then compounds 1 and 4 (each within the scatter of the next).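

In this assay, 4-fluorophenyl and 2-fluorophenyl on the amide-type nitrogen cannot be told apart (a number 7.4 percentage points higher from compound 1 to compound 4 (within the scatter)), so this position accepts fluorine at either printed place, whereas 3-bromophenyl does not hold the value (a number 65.4 percentage points higher from compound 3 to compound 4 (beyond the scatter)). The near-zero value of compound 2 thus does not come with the 4-fluorophenyl, since hydrogen in place of fluoro on an aromatic carbon restores the number (a number 66.3 percentage points higher from compound 2 to compound 4 (beyond the scatter)). Nothing given here explains these large steps. The compounds shown leave open how 3-fluorophenyl or 4-aminophenyl would behave on this nitrogen.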